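Chain extension on the sulfonamide in two polyamine cores

The source may hold more compounds than are shown below. What is called first, only, known or untested is meant among the compounds shown, and "the series" means these compounds.

In a functional assay on HEK293 cells (Homo sapiens) for inhibition (on this read-out lower numbers stand for stronger inhibition and higher numbers for weaker inhibition), compound 1 `CCCCCCCCS(=O)(=O)NCCCNCCCNCCCN` gives 5560 nM, and compound 2 `CCCCCCCCCCCCS(=O)(=O)NCCCNCCCNCCCN` gives 363 nM. The step between them, a 15-fold lower number from compound 1 to compound 2 (1.19 log units; beyond the scatter), comes from one change only: butyl in place of hydrogen on a saturated chain carbon, eight bonds along the chain from a sulfonyl sulfur.

Compound 3 `CCCCCCCCS(=O)(=O)NCCNCCCNCCN` carries a different core; how that core differs from the core of compound 1 is not broken down here. In this assay compound 3 gives 13800 nM, the highest number of the three measured compounds.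

Compound 4 `CCCCCCCCCCCCS(=O)(=O)NCCNCCCNCCN` is not yet measured. It differs from compound 3 by butyl in place of hydrogen on a saturated chain carbon, eight bonds along the chain from a sulfonyl sulfur, the same change that takes compound 1 to compound 2, at the same place along the chain. Among the compounds with values here, of this change only one measured instance exists, so whether it carries over to the second core is open; the expectation for compound 4 therefore rests on compound 1 and compound 2 alone, with the step of a 15-fold lower number from compound 1 to compound 2 (1.19 log units; beyond the scatter) as the template. In this assay compound 4 is expected to land near 1000 nM, within roughly 400 nM to 2500 nM, which would mean a step of a 14-fold lower number from compound 3 to compound 4 (1.14 log units; beyond the scatter).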

Compound 4, half-maximal inhibitory concentration: 686 nM
Compound 4: the middle estimate sits 1.5-fold (0.16 log units) above what was measured; measured number inside the range.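

In this assay the same butyl-for-hydrogen change, made on the core of compound 3, gives a 20-fold lower number from compound 3 to compound 4 (1.30 log units; beyond the scatter), and set beside the earlier step it reads: the same change on two cores in this assay, a 15-fold lower number (1.19 log units; beyond the scatter) from compound 1 to compound 2 and a 20-fold lower number (1.30 log units; beyond the scatter) from compound 3 to compound 4, 1.3-fold (0.12 log units) apart, within the scatter of two such steps. On these two cores the change therefore carries over with its size intact, and the difference between the cores does not show up in the size of the step. Within the data shown here, this rests on only two matched pairs and one chain extension, so it does not show that the step would hold on any further core or at any other chain length, and it gives no cause for the step.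

Among these compounds, still open is whether a longer chain than the one in compound 2 and compound 4 would lower the number further, or whether a shorter extension, such as methyl or ethyl in place of hydrogen, would give a proportionally smaller step. Also open, on these data alone, is whether a phenyl group in place of the butyl, or a carbonyl in place of the sulfonyl, would keep the step.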